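Halogen swap on the aryl piperazine of the shared core

The source may report more compounds than this note shows. Statements on the series, on what has been measured and on what is new or still open speak of the compounds shown alone.

Measured so far:
compound 1 `Fc1cc(Cl)ccc1N1CCN(Cc2ccn3c(CC4CC4)nnc3c2C(F)(F)F)CC1` gives 8.3 nM
compound 2 `Fc1ccc(N2CCN(Cc3cc(C(F)(F)F)cn4c(CC5CC5)nnc34)CC2)c(F)c1` gives 913 nM

In a functional assay on HEK293 cells for positive allosteric modulation of metabotropic glutamate receptor 2 (Homo sapiens), read by a luciferase reporter and cAMP accumulation, in the presence of a further agent that is not named here (a lower number here means that less compound is needed, a higher number that more compound is needed for the effect), compound 1 gives 8.3 nM, the lowest of the two numbers; compound 2 gives 913 nM, a gap beyond the scatter. Compound 3 `Fc1ccc(N2CCN(Cc3ccn4c(CC5CC5)nnc4c3C(F)(F)F)CC2)c(Cl)c1` is not yet measured. It differs from compound 1 by 2-chloro-4-fluorophenyl in place of 4-chloro-2-fluorophenyl on an amine nitrogen in a ring. Going by the values given here, no step between measured compounds covers this change; the gap between compound 1 and compound 2 shows only that the aryl substitution pattern matters. A moderate step upward is expected, with wide uncertainty. Compound 3 is estimated at 60 nM (10 nM to 400 nM), which means an expected step of a 7.2-fold higher number from compound 1 to compound 3 (0.86 log units; beyond the scatter).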

Compound 3, half-maximal effective concentration in the metabotropic glutamate receptor 2 assay: 11 nM
Compound 3: the middle estimate sits 5.5-fold (0.74 log units) above what was measured, and the stated range covers the measured number.
By their numbers in the metabotropic glutamate receptor 2 assay, from the lowest: compounds 1 and 3 (each within the scatter of the next); then compound 2.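

Exchanging 4-chloro-2-fluorophenyl for 2-chloro-4-fluorophenyl on the piperazine amine nitrogen is tolerated in the metabotropic glutamate receptor 2 assay: a 1.3-fold higher number from compound 1 to compound 3 (0.12 log units; within the scatter). The same exchange does separate the pair in a physicochemical assay for lipophilicity, read by HPLC, in phosphate buffer, measured as octanol-water partition, at pH 7.4; on this read-out higher numbers stand for higher lipophilicity and lower numbers for lower lipophilicity: the measured distribution coefficient of compound 1, 4.01, and of compound 3, 3.38, a number 0.63 log units lower (beyond the scatter). In the physicochemical assay compound 1 gives 4.01 and compound 3 gives 3.38. For this pair, then, the two halogens can change places with a shift in the distribution coefficient and no shift beyond the scatter in the metabotropic glutamate receptor 2 assay.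

As far as these compounds go, whether a phenyl bearing a nitrile or a methoxy group in place of either halogen would hold the number in the metabotropic glutamate receptor 2 assay remains open. Two compounds also give no general rule for this position.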